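Hydroxy in place of chloro: compound 3 to compound 4

The source may report more compounds than this note shows. Statements on the series, on what has been measured and on what is new or still open speak of the compounds shown alone.

In a functional assay on KB cells (Homo sapiens) for antiproliferative activity, read by colorimetric assay and MTT assay (a lower number here means a stronger inhibitor, a higher number a weaker inhibitor), compound 3 `Nc1ccc(S(=O)(=O)Nc2cccc3cc(Cl)[nH]c23)cc1` gives 1.4 ug/mL and compound 1 `O=S(=O)(Nc1cccc2cc(O)[nH]c12)c1ccc(Cl)cc1` gives 1.1 ug/mL and these two values lie within the scatter of each other. Compound 2 `O=[N+]([O-])c1ccc(S(=O)(=O)Nc2cccc3cc(O)[nH]c23)cc1` gives > 100 ug/mL and that value is a limit of the assay. On the numbers shown, compound 3 therefore stands together with compound 1.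

Compound 4 `Nc1ccc(S(=O)(=O)Nc2cccc3cc(O)[nH]c23)cc1` differs from compound 3 by hydroxy in place of chloro on an aromatic carbon of a five-membered aromatic ring with 1 nitrogen, next to the ring nitrogen (hydroxy in place of chloro on an aromatic carbon). Going by the values given here, no measured step covers this exchange. Among the compounds with values here, the only step available is large and concerns a different exchange, nitro in place of chloro on an aromatic carbon (an at least 90-fold higher number from compound 1 to compound 2 (1.95 log units; beyond the scatter)), so it gives no size for the present change. The closest guide is compound 1, which carries the entering hydroxy and still reads 1.1 ug/mL in this assay and on that basis no step beyond the scatter is expected, in either direction. The range is kept wide because no direct comparison exists.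

The estimated step is a 1.4-fold higher number from compound 3 to compound 4 (0.15 log units; within the scatter) and it remains an expectation. For compound 4 the expected value is 2 ug/mL (estimated range 0.3 ug/mL to 15 ug/mL).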

Compound 4, half-maximal inhibitory concentration: 0.86 ug/mL
Estimate against measurement, compound 4: 2.3-fold (0.37 log units) above; measured number inside the range.
By their numbers in this assay, from the lowest: compounds 4, 1 and 3 (each within the scatter of the next). At a limit, above all of these: compound 2.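

In this assay, going by these compounds alone, hydroxy in place of chloro on an aromatic carbon of the five-membered aromatic ring with 1 nitrogen, next to the ring nitrogen, gives a 1.6-fold lower number from compound 3 to compound 4 (0.21 log units; within the scatter), the first direct reading at this position; on this single pair, the two groups cannot be told apart. Swapping chloro for amino at the other site gives a 1.3-fold lower number from compound 1 to compound 4 (0.11 log units; within the scatter), so with hydroxy held fixed, amino and chloro also read alike, and nitro remains the only group among those shown that goes with a large change. Amino in place of nitro on an aromatic carbon gives an at least 110-fold lower number from compound 2 to compound 4 (2.06 log units; beyond the scatter), and that step is a bound, since its starting value is a limit of the assay: the limit of > 100 ug/mL in this assay, at which 1 of the 4 values shown sits.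

The compounds shown leave open whether this flat reading next to the ring nitrogen extends to groups other than chloro and hydroxy, such as methyl or methoxy. Going by these compounds, it is also open whether the large change belongs to nitro alone or also appears with another group on that aromatic carbon, such as a nitrile or a carboxylic acid.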